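Benzothiazole amides: chloro to methyl on the fused ring

The source may report more compounds than this note shows. Statements on the series, on what has been measured and on what is new or still open speak of the compounds shown alone.

Measured so far: compound 1 `Cc1ccc2nc(NC(=O)c3cn(-c4ccccc4)nc3-c3ccc(Cl)cc3)sc2c1`, 14500 nM; compound 2 `COc1ccc(-c2nn(-c3ccccc3)cc2C(=O)Nc2nc3ccccc3s2)cc1`, 6670 nM; compound 3 `COc1ccc(-c2nn(-c3ccccc3)cc2C(=O)Nc2nc3ccc(Cl)cc3s2)cc1`, 6510 nM.

In a functional assay on PC-3 cells (Homo sapiens) for cytotoxicity, read by MTT assay, with a stated time of 72 h (a higher number here means a weaker inhibitor, a lower number a stronger inhibitor), compound 3 gives the lowest of the three numbers, with compound 2 within the scatter of it and only compound 1 beyond it. Compound 4 `COc1ccc(-c2nn(-c3ccccc3)cc2C(=O)Nc2nc3ccc(C)cc3s2)cc1` differs from compound 3 by methyl in place of chloro on an aromatic carbon. Among the compounds with values here, the only step on that carbon is a 1.0-fold lower number from compound 2 to compound 3 (0.01 log units; within the scatter), which was flat. Compound 1 carries the methyl but differs elsewhere too, so its number says little here. No step beyond the scatter is expected; compound 4 is estimated at 8000 nM (range 3500 nM to 18000 nM), meaning the step of a 1.2-fold higher number from compound 3 to compound 4 (0.09 log units; within the scatter) is expected.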

Compound 4, half-maximal inhibitory concentration: 15900 nM
Beside the measured number, compound 4's estimate is 2.0-fold (0.30 log units) below it; measured number inside the range.
By their numbers in this assay, from the lowest: compounds 3 and 2 (each within the scatter of the next); then compounds 1 and 4 (each within the scatter of the next).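

In this assay the aromatic carbon that looked flat for chloro in place of hydrogen does respond to methyl: a 2.4-fold higher number from compound 3 to compound 4 (0.39 log units; beyond the scatter), and a 2.4-fold higher number from compound 2 to compound 4 (0.38 log units; beyond the scatter), so hydrogen and chloro stand together and methyl apart. With the 6-methyl-1,3-benzothiazol-2-yl group kept, methoxy in place of chloro elsewhere gives a 1.1-fold higher number from compound 1 to compound 4 (0.04 log units; within the scatter), so that exchange does not separate the two compounds. No measured property is at hand to account for the methyl step. On these data alone, whether fluoro or an amine on this carbon falls with hydrogen and chloro or with methyl remains open.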